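Swapping a branched chain for a halogenated benzyl group

The compounds below may be only part of what the source reports. "The series", "measured", "known", "first", "only" and "open" are said of these compounds alone.

Measured compounds:
- compound 1, `CCC(CC)c1ccc2c(NCCCNCc3cccc(OC)c3O)ccnc2c1`: 9.47
- compound 2, `COc1ccc(F)cc1CNCCCNc1ccnc2cc(Cc3ccc(F)cc3)ccc12`: 9.47
- compound 3, `CCC(CC)c1ccc2c(NCCCNCc3cc(F)ccc3OC)ccnc2c1`: 9.47

In a physicochemical assay for acid dissociation, compound 1 gives 9.47 and stands level with compounds 2 and 3 at the digits shown; the three values sit within the scatter of one another, so no order among them can be read. The step of no change at the digits printed from compound 1 to compound 3 (within the scatter) shows that exchanging the substituted benzyl group on the amine leaves the read-out untouched, and the step of no change at the digits printed from compound 2 to compound 3 (within the scatter) shows the same for exchanging the group on the aromatic carbon of the shared core.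

Compound 4, `COc1cccc(CNCCCNc2ccnc3cc(Cc4ccc(F)cc4Cl)ccc23)c1O`, has not yet been measured. It differs from compound 1 as follows: 2-chloro-4-fluorobenzyl in place of pentan-3-yl on an aromatic carbon. The step from compound 2 to compound 3 bears directly on this change, since it also swaps a benzyl group against pentan-3-yl at that aromatic carbon, and it showed no change. Going by the values given here, no measured step therefore points to a shift beyond the scatter in this assay.

Compound 4 is thus expected to give 9.47, within a range of 9.2 to 9.75, which means an expected step of no change at the digits printed from compound 1 to compound 4 (within the scatter).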

Compound 4, acid dissociation constant: 9.47
The estimate for compound 4 equals the measured number at the digits printed; the measured number falls inside the stated range.
By their numbers in this assay, from the lowest: compounds 1, 2, 3 and 4 (each within the scatter of the next).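

With 2-chloro-4-fluorobenzyl in place of pentan-3-yl on an aromatic carbon of the shared core, this assay shows no change at the digits printed from compound 1 to compound 4 (within the scatter) for this exchange. The earlier step at this position involved 4-fluorobenzyl and compounds carrying 5-fluoro-2-methoxyphenyl on the chain, so this result adds two things: the same outcome holds with 2-hydroxy-3-methoxyphenyl on the chain, and it holds for a benzyl group that also carries chlorine, with 9 heavy atoms and a six-membered aromatic ring entering where 5 heavy atoms and no ring leave. No supporting evidence is available to explain this result.

All the groups shown at this aromatic carbon are built from carbon, with or without halogen on a benzyl ring, so it remains open whether an amine or a carboxylic acid placed there would leave the read-out of this assay equally undisturbed. A longer chain linking the two amine nitrogens is also untested among these compounds, and so the read-out's response to a change in that part of the molecule remains unknown.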